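Lengthening the but-1-en-1-yl chain of compound 3

A few compounds are considered here, and "the series" means these few. Any claim that something is new, unique, unknown or untested is made for them only; others in the source may bear on it.

In a functional assay on A549 cells (Homo sapiens) for inhibition, read by MTT assay, with a stated time of 72 h (on this read-out lower numbers stand for stronger inhibition and higher numbers for weaker inhibition), compound 1 `COc1cc(N(C)CCN(C)C)c(NC(=O)C=C(C)C)cc1Nc1nc2c(c(-c3cn(C)c4ccc(F)cc34)n1)CSCC2` gives 902 nM, compound 2 `C/C=C\C(=O)Nc1cc(Nc2nc3c(c(-c4cn(C)c5ccc(F)cc45)n2)CSCC3)c(OC)cc1N(C)CCN(C)C` gives 5310 nM and compound 3 `CC/C=C\C(=O)Nc1cc(Nc2nc3c(c(-c4cn(C)c5ccc(F)cc45)n2)CSCC3)c(OC)cc1N(C)CCN(C)C` gives 1450 nM. Compound 3 falls with the lower pair of numbers: a 1.6-fold higher number from compound 1 to compound 3 (0.21 log units; within the scatter), against a 3.7-fold lower number from compound 2 to compound 3 (0.56 log units; beyond the scatter).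

Compound 4 `CCC/C=C\C(=O)Nc1cc(Nc2nc3c(c(-c4cn(C)c5ccc(F)cc45)n2)CSCC3)c(OC)cc1N(C)CCN(C)C` carries methyl in place of hydrogen on a saturated chain carbon, two bonds along the chain from a double-bonded chain carbon, giving pent-1-en-1-yl. Within the data shown here, the only measured step of this kind is the 2>3 change, methyl in place of hydrogen on a saturated chain carbon bound to a double-bonded chain carbon. A smaller step in the same direction is expected in this assay, probably none beyond the scatter. The expected step is a 1.2-fold lower number from compound 3 to compound 4 (0.08 log units; within the scatter). The estimate for compound 4 is 1200 nM, with an expected range of 450 nM to 3200 nM.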

Compound 4, half-maximal inhibitory concentration: 5190 nM
Beside the measured number, compound 4's estimate is 4.3-fold (0.64 log units) below it; measured number outside the range, above it.
By their numbers in this assay, from the lowest: compounds 1 and 3 (each within the scatter of the next); then compounds 4 and 2 (each within the scatter of the next).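

In (this assay), methyl in place of hydrogen, two bonds along the chain from a double-bonded chain carbon, gives (a 3.6-fold higher number from compound 3 to compound 4 (0.55 log units; beyond the scatter)), the opposite direction to the earlier methyl step (a 3.7-fold lower number from compound 2 to compound 3 (0.56 log units; beyond the scatter)), so the response at this position does not run one way with chain length. Pent-1-en-1-yl stands level with prop-1-en-1-yl (a 1.0-fold lower number from compound 2 to compound 4 (0.01 log units; within the scatter)) and clear of 2-methylprop-1-en-1-yl (a 5.8-fold higher number from compound 1 to compound 4 (0.76 log units; beyond the scatter)). Nothing at hand accounts for this reversal.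

From the compounds shown here alone, whether a longer chain such as hex-1-en-1-yl stays at this level remains open, as does the effect of an amine at the chain end.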